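This account rests on a few compounds, and the source may have more. Where it says the series, first, only, none or still open, it means among the compounds named here.

Measured so far:
compound 1, `COc1ccc(-n2cnc3cnc(Nc4cccc(NC(C)=O)c4)cc32)cc1OC`: 140 nM
compound 2, `COc1ccc(-n2cnc3cnc(Oc4cccc(NC(C)=O)c4)cc32)cc1OC`: > 30000 nM
compound 3, `Cc1cccc(C)c1-c1cc2c(cn1)ncn2-c1ccc(OC(F)F)cc1`: 980 nM

In a functional assay on HL-60 cells (Homo sapiens) for activation, read by flow cytometry, with a stated time of 4 days (on this read-out higher numbers stand for an effect only at larger amounts of compound and lower numbers for an effect already at smaller amounts), compound 3 holds the highest of the two numbers shown; compound 1 gives a lower number, and that gap lies beyond the scatter. Compound 2 reaches only a limit of this assay, (the limit of > 30000 nM in this assay, at which 1 of the 3 values shown sits), and so gives no number.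

Compound 4, `Cc1cc(F)ncc1-c1cc2c(cn1)ncn2-c1ccc(OC(F)F)cc1`, has not yet been measured. It differs from compound 3 in one place: a group of 8 heavy atoms (6 carbon, 1 nitrogen, 1 fluorine; one six-membered aromatic ring with 1 hetero atom) in place of a group of 8 heavy atoms (8 carbon; one six-membered aromatic ring of carbon only), on an aromatic carbon.

No measured step of this kind is available among the compounds shown, so the size of the step is uncertain; a step within the scatter or a moderate one in either direction seems plausible. For compound 4 the expected value in this assay is 800 nM, between 200 nM and 3000 nM, which would mean an estimated step of a 1.2-fold lower number from compound 3 to compound 4 (0.09 log units; within the scatter).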

Compound 4, half-maximal effective concentration: 1200 nM
Compound 4: middle estimate off by 1.5-fold (0.18 log units), on the low side; the measured number falls inside the stated range.
By their numbers in this assay, from the lowest: compound 1; then compounds 3 and 4 (each within the scatter of the next). At a limit, above all of these: compound 2.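

In this assay, replacing the 2,6-dimethylphenyl group with a six-membered aromatic ring carrying one nitrogen and one fluorine gives a 1.2-fold higher number from compound 3 to compound 4 (0.09 log units; within the scatter). At this aromatic carbon, then, a ring with a hydrogen-bond acceptor reads the same as a ring of carbon only, despite the new ring atom and the fluorine. Nothing measured here explains why the two rings read alike. The compounds shown leave open whether a morpholine or a simple amine on this carbon would move the number beyond the scatter.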